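The compounds below may be only part of what the source reports. "The series", "measured", "known", "first", "only" and "open" are said of these compounds alone.

Measured in a functional assay on MGC-803 cells (Homo sapiens) for inhibition, read by MTT assay, with a stated time of 48 h; on this read-out lower numbers stand for stronger inhibition and higher numbers for weaker inhibition:
- compound 1 `COc1ccc(-c2coc3cc(OCCCSC(=S)N4CCN(C)CC4)ccc3c2=O)cc1`: 21900 nM
- compound 2 `CCN1CCN(C(=S)SCCCOc2ccc3c(=O)c(-c4ccc(OC)cc4)coc3c2)CC1`: 54000 nM
- compound 3 `COc1ccc(-c2coc3cc(OCCCSC(=S)N4CCN(C(C)=O)CC4)ccc3c2=O)cc1`: 39400 nM

The three compounds differ only in the group on an amine nitrogen in a ring. Compound 3, at 39400 nM, lies within the scatter of both others. Only compound 1 and compound 2 are separated beyond it.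

The next compound is compound 4 `COc1ccc(-c2coc3cc(OCCCSC(=S)N4CCN(c5ccccn5)CC4)ccc3c2=O)cc1`, with pyridin-2-yl in place of acetyl on an amine nitrogen in a ring.

Among the compounds with values here, three measured steps bear on this place. Acetyl in place of methyl gave a 1.8-fold higher number from compound 1 to compound 3 (0.26 log units; within the scatter), and acetyl in place of ethyl gave a 1.4-fold lower number from compound 2 to compound 3 (0.14 log units; within the scatter). Ethyl in place of methyl gave a 2.5-fold higher number from compound 1 to compound 2 (0.39 log units; beyond the scatter), the only one beyond the scatter, and modest in size. Within the data shown here, all three are small, but no measured compound carries a ring on that nitrogen, so this evidence is indirect and the range must stay wide.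

In this assay a step of similar small size is expected, probably none beyond the scatter, with only a slight lean towards a lower number. The expected change is a 1.4-fold lower number from compound 3 to compound 4 (0.15 log units; within the scatter). For compound 4 the estimated value is 28000 nM, with an expected range of 9000 nM to 70000 nM.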

Compound 4, half-maximal inhibitory concentration: 42000 nM
Compound 4: the middle estimate sits 1.5-fold (0.18 log units) below what was measured; the range from low to high includes it.
By their numbers in this assay, from the lowest: compounds 1, 3, 4 and 2 (each within the scatter of the next, the first and the last beyond it).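

In this assay, the first ring on the amine nitrogen of the piperazine gives no step beyond the scatter: pyridin-2-yl in place of acetyl gives a 1.1-fold higher number from compound 3 to compound 4 (0.03 log units; within the scatter), in place of ethyl it gives a 1.3-fold lower number from compound 2 to compound 4 (0.11 log units; within the scatter), and in place of methyl it gives a 1.9-fold higher number from compound 1 to compound 4 (0.28 log units; within the scatter). Within the data shown here, this position therefore accepts a six-membered aromatic ring, with 6 heavy atoms against the 3 of acetyl, without compound 4 separating from any of the three earlier compounds, and compound 1 and compound 2 remain the only pair set apart beyond the scatter. No measurement shown offers an explanation for this result.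

Still open, from the compounds shown here alone, is whether any group on this nitrogen can move the number clearly below that of compound 1, for example a phenyl or benzyl group, a plain hydrogen, or a pyridine ring joined through another of its carbons. The compounds shown also say nothing about a longer chain or about a change to the methoxy group on the shared core, as every compound here carries both unchanged.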